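Swapping Methyl for Acetamido on Compound 3

This account rests on a few compounds, and the source may have more. Where it says the series, first, only, none or still open, it means among the compounds named here.

In a functional assay on HL-60 cells (Homo sapiens) for inhibition, read by CCK-8 assay, with a stated time of 48 h, tested at 20 uM (on this read-out higher numbers stand for more inhibition of growth at the one concentration tested and lower numbers for less inhibition of growth), compound 1 `Cc1ccc(S(=O)(=O)Oc2cccc(/C=C(\C#N)C(=O)Nc3nnc(C)s3)c2)cc1` gives 71% and compound 2 `Cc1ccc(S(=O)(=O)Oc2cccc(/C=C(\C#N)C(=O)Nc3nnc(-c4ccccc4Cl)s3)c2)cc1` gives 67% while compound 3 `Cc1ccc(S(=O)(=O)Oc2cccc(/C=C(\C#N)C(=O)Nc3nnc(-c4cccs4)s3)c2)cc1` gives 62% and so lies within the scatter of both. Compound 4 `CC(=O)Nc1ccc(S(=O)(=O)Oc2cccc(/C=C(\C#N)C(=O)Nc3nnc(-c4cccs4)s3)c2)cc1` differs from compound 3 by acetamido in place of methyl on an aromatic carbon in the form of acetamido in place of methyl on an aromatic carbon, para to a large group. Three measured steps offer only indirect guidance. Each alters a different group and leaves this methyl in place. They are a number 4 percentage points lower from compound 1 to compound 2 (within the scatter) and a number 9 percentage points lower from compound 1 to compound 3 (within the scatter) and a number 5 percentage points lower from compound 2 to compound 3 (within the scatter) and all stay within the scatter. No step beyond the scatter is therefore expected, and the estimated change is a number 2 percentage points lower from compound 3 to compound 4 (within the scatter) in this assay as a working figure. For compound 4 the expected value is 60% with an estimated range from 46% to 74% as the likely span.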

Compound 4, percent growth inhibition at one concentration: 71%
For compound 4 the middle estimate is 11 percentage points below the measured one; measured number inside the range.
By their numbers in this assay, from the lowest: compounds 3, 2, 1 and 4 (each within the scatter of the next).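

In this assay, within the data shown here, the step at this place reads a number 9 percentage points higher from compound 3 to compound 4 (within the scatter) and is the first measured change to the 4-methylphenyl group. It shows that acetamido, with its hydrogen-bond donor and acceptor, can stand in place of methyl, para to a large group, without a step beyond the scatter. Nothing available explains this result.

As far as these compounds go, whether an amine, a carboxylic acid or a longer chain would also stay within the scatter here remains open. So does whether acetamido gives the same result with the methyl of compound 1 or the 2-chlorophenyl of compound 2 in place of thiophen-2-yl.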